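The compounds below may be only part of what the source reports. "The series", "measured", "known", "first", "only" and "open" are said of these compounds alone.

Of the compounds shown here, three have been measured in a functional assay on A549 cells (Homo sapiens), read by MTT assay, with a stated time of 72 h; a higher number here means a weaker inhibitor, a lower number a stronger inhibitor. Compound 1 `COc1ncnc2c1c(-c1ccoc1)cn2[C@@H]1O[C@H](CO)[C@@H](O)[C@H]1O` gives 1160 nM. Compound 2 `Cc1ncnc2c1c(-c1ccoc1)cn2[C@@H]1O[C@H](CO)[C@@H](O)[C@H]1O` gives > 20000 nM, which is a limit of this assay and not a number (the limit of > 20000 nM in this assay, at which 1 of the 3 values shown sits). Compound 3 `COc1ncnc2c1c(-c1cccs1)cn2[C@@H]1O[C@H](CO)[C@@H](O)[C@H]1O` gives 4850 nM.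

The core of compound 1 and the core of compound 3 differ in one place: thiophen-2-yl in place of furan-3-yl on an aromatic carbon. This step gives a 4.2-fold higher number from compound 1 to compound 3 (0.62 log units; beyond the scatter) in this assay.

The change from compound 1 to compound 2 is methyl in place of methoxy on an aromatic carbon. It produces an at least 17-fold higher number from compound 1 to compound 2 (1.23 log units; beyond the scatter).

Compound 4 `Cc1ncnc2c1c(-c1cccs1)cn2[C@@H]1O[C@H](CO)[C@@H](O)[C@H]1O` has not yet been measured. It differs from compound 3 in the same way: methyl in place of methoxy on an aromatic carbon. Since the surroundings of the change match word for word those between compound 1 and compound 2, the same change is made on the core of compound 3. Compound 4 is therefore expected to show a 12-fold higher number from compound 3 to compound 4 (1.09 log units; beyond the scatter), resting on the step of an at least 17-fold higher number from compound 1 to compound 2 (1.23 log units; beyond the scatter), which carried compound 2 to a limit of this assay. Compound 4 is estimated at 60000 nM, with a range from 20000 nM to 200000 nM, most likely reported only as a limit.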

Compound 4, half-maximal inhibitory concentration: > 20000 nM
Compound 4: only a limit was reported (the forecaster's own chance of this, stated with the estimate: 85%); the middle value is on the limit's open side.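

In this assay compound 4 gives > 20000 nM, which is a limit of the assay and not a number. Methyl in place of methoxy gives an at least 4.1-fold higher number from compound 3 to compound 4 (0.61 log units; beyond the scatter), so on both cores the change moves the number upward by more than the scatter: the same change on two cores in this assay, an at least 17-fold higher number (1.23 log units; beyond the scatter) from compound 1 to compound 2 and an at least 4.1-fold higher number (0.61 log units; beyond the scatter) from compound 3 to compound 4; the limit leaves it open whether they differ

This shows that the direction of the change carried from the core of compound 1 to the core of compound 3, but it does not give the full size of the step on either core. The step between compound 2 and compound 4 cannot be read, so nothing shows whether thiophen-2-yl and furan-3-yl still differ once methyl is present: the limit of > 20000 nM in this assay, at which 2 of the 4 values shown sit.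

The compounds shown leave open how an amine or a longer chain in place of methoxy would read in this assay. They also leave open whether any such group would give a number below the limit.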